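The source may hold more compounds than are shown below. What is called first, only, known or untested is meant among the compounds shown, and "the series" means these compounds.

Of the three compounds tested in a functional assay on BXPC-3 cells (Homo sapiens) for inhibition, read by XTT assay, with a stated time of 72 h (on this read-out lower numbers stand for stronger inhibition and higher numbers for weaker inhibition), compound 1 `CCCCCCCC/C=C\CCCCCCCCOC[C@@H]1CCCN1C(=O)OC(C)(C)C` returns only a limit, > 100000 nM. Compound 2 `CC(C)(C)OC(=O)N1CCC[C@H]1COCCCCCCCCC/C=C/c1ccc(-c2ccccc2)cc1` gives 60000 nM and compound 3 `CC(C)(C)OC(=O)NCC(=O)N1CCC[C@H]1COCCCCCC/C=C/c1ccc(-c2ccccc2)cc1` gives 66700 nM. These two numbers lie within the scatter of each other, so neither compound can be ranked over the other. Compound 4 `CC(C)(C)OC(=O)NCC(=O)N1CCC[C@H]1COCCCCCCCCC/C=C/c1ccc(-c2ccccc2)cc1` differs from compound 2 by having ((tert-butoxycarbonyl)amino)methyl in place of tert-butoxy on a carbonyl carbon. Among the compounds with values here, no measured step shows what this change does in this assay, so no shift beyond the scatter is expected, in either direction. The estimated step, a 1.2-fold lower number from compound 2 to compound 4 (0.08 log units; within the scatter), is correspondingly small. For compound 4 the expected value is 50000 nM, with an estimated range from 20000 nM to 100000 nM.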

Compound 4, half-maximal inhibitory concentration: > 100000 nM
Compound 4 gave a limit, no number; the forecaster's own chance of this, stated with the estimate: 15%; at least 2.0-fold (0.30 log units) between middle value and limit.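

The change of tert-butoxy to ((tert-butoxycarbonyl)amino)methyl on a carbonyl carbon can now be read in this assay, and it gives an at least 1.6-fold higher number from compound 2 to compound 4 (0.22 log units; that floor lies within the scatter). As far as these compounds go, compound 4 returns a limit, not a number, so this step is only a floor and its full size remains unknown. The reading therefore offers no sign of a gain from this change, and it ends at a ceiling shared with another compound: the limit of > 100000 nM in this assay, at which 2 of the 4 values shown sit.

The compounds shown leave open whether a free amine or a carboxylic acid on this carbonyl carbon would give a measurable number in this assay.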